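This account rests on a few compounds, and the source may have more. Where it says the series, first, only, none or still open, it means among the compounds named here.

Measured compounds:
compound 1 `COc1ccc(C(=O)O)cc1OCCCCOc1ccc(C(=O)CC(C)C)c(O)c1C` — 100%
compound 2 `Cc1c(OCCCCOc2cccc(C(=O)O)c2)ccc(C(=O)CC(C)C)c1O` — 69.9%

Of the compounds shown here, two built on the shared core have been tested in an assay on HEK293 cells for positive allosteric modulation of metabotropic glutamate receptor 3 (Rattus norvegicus), read by thallium flux, with a stated time of 2.5 min; a lower number here means a smaller maximal response, a higher number a larger maximal response. Compound 1, `COc1ccc(C(=O)O)cc1OCCCCOc1ccc(C(=O)CC(C)C)c(O)c1C`, gives 100% in this assay and stands highest of the two numbers. Compound 2, `Cc1c(OCCCCOc2cccc(C(=O)O)c2)ccc(C(=O)CC(C)C)c1O`, gives 69.9% in this assay. Going by the values given here, the single measured step is a number 30.1 percentage points lower from compound 1 to compound 2 (beyond the scatter), and it lies beyond the scatter.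

Compound 3, `CCC(=O)c1ccc(OCCCCOc2cc(C(=O)O)ccc2OC)c(C)c1O`, has not yet been measured in this assay. It differs from compound 1 at another place: methyl in place of isopropyl on a saturated chain carbon bound to a carbonyl carbon. Among the compounds with values here, the measured step from compound 1 to compound 2 concerns a different position and different groups, so it does not bear on this change, and no measured pair shows what exchanging the group on the saturated chain carbon bound to the carbonyl carbon does. In the absence of any bearing step, the expectation can only rest on compound 1 as the starting point. Compound 3 is therefore expected to give about 85% in this assay. The expected range for compound 3 runs from 60% to 105%. The expected step, a number 15 percentage points lower from compound 1 to compound 3 (beyond the scatter), is judged to lie within or only slightly beyond the scatter.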

Compound 3, largest response reached (reported as percent of maximum), in percent of the reference or control that the assay uses: 62.5%
Beside the measured number, compound 3's estimate is 22.5 percentage points above it; low and high end bracket the measured number.
By their numbers in this assay, from the lowest: compounds 3 and 2 (each within the scatter of the next); then compound 1.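

In this assay, the exchange of isopropyl for methyl on a saturated chain carbon bound to a carbonyl carbon gives a number 37.5 percentage points lower from compound 1 to compound 3 (beyond the scatter) and thereby turns the isobutylcarbonyl group of compound 1 into propanoyl. The earlier compounds shown here showed only what hydrogen in place of methoxy does at another place, whereas this result shows that a single change at this second place also moves the maximal response beyond the scatter, so that the read-out does not depend on the methoxy place alone. Nothing available here explains why this exchange has such an effect.

With only isopropyl and methyl compared at this place, the compounds shown leave open whether the response changes steadily with the carbon count of the group or whether a longer chain, such as an n-butyl group, or a cyclopropyl ring would bring it back towards that of compound 1. They also leave open what a hydroxyl group or an amine at this place would do, and whether this exchange and the loss of methoxy would combine in a single molecule.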